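Chloro Substitution on Two Related Cores

The source may hold more compounds than are shown below. What is called first, only, known or untested is meant among the compounds shown, and "the series" means these compounds.

compound 1 `CCOC(=O)C1=C(C)N(c2ccccc2)C=CC1c1ccccc1`: -37.1%
compound 2 `CCOC(=O)C1=C(C)N(c2ccc(Cl)cc2)C=CC1c1ccccc1`: -34.4%
compound 3 `COC(=O)C1=C(C)N(c2ccccc2)C=C(C)C1c1ccccc1`: -37.4%

In a functional assay for inhibition, using microsomes, tested at 200 ug/mL (on this read-out lower numbers stand for a stronger effect and higher numbers for a weaker effect at the one concentration tested), compound 1 gives -37.1%, compound 2 gives -34.4% and compound 3 gives -37.4%. Compound 2 differs from compound 1 by chloro in place of hydrogen on an aromatic carbon, and this change made a step of a number 2.7 percentage points higher from compound 1 to compound 2 (within the scatter). Compound 3 has the same atoms as compound 1 joined differently; the difference between the two cores is not broken down here.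

Compound 4 `COC(=O)C1=C(C)N(c2cccc(Cl)c2)C=C(C)C1c1ccccc1` has not yet been measured in this assay. It differs from compound 3 by chloro in place of hydrogen on an aromatic carbon. This is the same kind of change as that from compound 1 to compound 2, but here the chloro sits meta to a large group, whereas in compound 2 it sits para to a large group.

A step of a number 2.4 percentage points higher from compound 3 to compound 4 (within the scatter) is expected in this assay, because the earlier step of a number 2.7 percentage points higher from compound 1 to compound 2 (within the scatter) lay within the scatter. Compound 4 is therefore expected to give about -35%, with a range from -46% to -24%.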

Compound 4, a percentage reported as activity, at one concentration (the size of the read-out at that concentration, not a potency): -22.8%
Compound 4: the middle estimate sits 12.2 percentage points below what was measured; measured number outside the range, above it.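

In this assay, chloro in place of hydrogen on an aromatic carbon gave a step of a number 14.6 percentage points higher from compound 3 to compound 4 (beyond the scatter). Within the data shown here, although this step is larger than the earlier one, the gap between them does not exceed what two such steps can show by scatter, so the change cannot be said to behave differently on the two cores: the same change on two cores in this assay, a number 2.7 percentage points higher (within the scatter) from compound 1 to compound 2 and a number 14.6 percentage points higher (beyond the scatter) from compound 3 to compound 4, 11.9 percentage points apart, within the scatter of two such steps Nor does this show that the change carries over unaltered, since only two pairs are available and the chloro of compound 4 sits meta to a large group while that of compound 2 does not, leaving core and position entangled.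

The compounds shown leave open how 3-chlorophenyl would read on the core of compound 1. They also leave open how an amine or a carboxylic acid in place of the chloro would read in this assay.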